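The source may report more compounds than this note shows. Statements on the series, on what has been measured and on what is new or still open speak of the compounds shown alone.

Within the data shown here, in a functional assay on Huh-5-2 cells (Homo sapiens) for cytotoxicity, read by microscopy (a higher number here means that more compound is tolerated, a lower number that less compound is tolerated), compound 1 `CC(=O)OC[C@H]1O[C@@H](n2c(SCc3cc4ccccc4oc3=O)nc3cncnc32)[C@H](OC(C)=O)[C@@H]1OC(C)=O` gives 39000 nM, the highest of the three numbers so far. Compound 2 `CC(=O)OC[C@H]1O[C@@H](n2c(SCc3cc4cc(Cl)ccc4oc3=O)nc3cncnc32)[C@H](OC(C)=O)[C@@H]1OC(C)=O` gives 7500 nM and compound 3 `CC(=O)OC[C@H]1O[C@@H](n2c(SCc3cc4cc(Br)ccc4oc3=O)nc3cncnc32)[C@H](OC(C)=O)[C@@H]1OC(C)=O` gives 6700 nM. Chloro in place of hydrogen on an aromatic carbon is a 5.2-fold lower number from compound 1 to compound 2 (0.72 log units; beyond the scatter), and bromo in place of hydrogen on an aromatic carbon is a 5.8-fold lower number from compound 1 to compound 3 (0.76 log units; beyond the scatter). Both lie beyond the scatter, whereas a 1.1-fold lower number from compound 2 to compound 3 (0.05 log units; within the scatter) stays within it. Compound 4 `COc1cccc2cc(CSc3nc4cncnc4n3[C@@H]3O[C@H](COC(C)=O)[C@@H](OC(C)=O)[C@H]3OC(C)=O)c(=O)oc12` differs from compound 1 by methoxy in place of hydrogen on an aromatic carbon. Among the measured compounds shown here, no methoxy compound has been measured, so only the two halogen steps guide the expectation of a lower number, by a smaller step than theirs. The expected step is a 2.0-fold lower number from compound 1 to compound 4 (0.29 log units; within the scatter). For compound 4 the estimate is 20000 nM, with an expected range from 7000 nM to 50000 nM.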

Compound 4, half-maximal cytotoxic concentration: 7500 nM
For compound 4 the middle estimate is 2.7-fold (0.43 log units) above the measured one; the range from low to high includes it.
By their numbers in this assay, from the lowest: compounds 3, 2 and 4 (each within the scatter of the next); then compound 1.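

In this assay, methoxy in place of hydrogen, on an aromatic carbon ortho to a fused ring and meta to a fused ring, gives a 5.2-fold lower number from compound 1 to compound 4 (0.72 log units; beyond the scatter). A step beyond the scatter from compound 1 is therefore not confined to the two halogens, since this non-halogen group also lowers the number. No measurement shown here offers an explanation for this step.

The compounds shown leave open whether a hydroxyl, an amine or a longer chain such as ethoxy at this place would give a similar step. They also leave open how methoxy would behave on the other aromatic carbons of this ring.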